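A few compounds are considered here, and "the series" means these few. Any claim that something is new, unique, unknown or untested is made for them only; others in the source may bear on it.

Measured compounds, with their results in an assay on isolated protein for binding affinity to corticotropin-releasing factor receptor 1 (Homo sapiens); a lower number here means a stronger inhibitor, a higher number a weaker inhibitor:

Compound 1, `CC(=O)/C(=N\Nc1ccccc1C)N(C)c1cccc(Cl)c1`: for compound 1 the result is a limit, > 10000 nM (the limit of > 10000 nM in this assay, at which 1 of the 2 values shown sits).
Compound 2, `CC(=O)/C(=N\c1ccccc1)NNc1ccccc1C`: in this assay compound 2 gives 526 nM.

Among the compounds with values here, of the two results in this assay, compound 2 thus holds the only actual number; compound 1 gives a limit rather than a value. Compound 3, `CC(=O)/C(=N\c1cccc(C)c1)NNc1ccccc1C`, differs from compound 2 in one place: methyl in place of hydrogen on an aromatic carbon. Within the data shown here, no measured pair shows the effect of such a change in this assay, so there is nothing to scale the step from. A small methyl added to an aromatic ring is expected to move the inhibition constant only modestly, within the usual scatter in either direction. The step from compound 2 to compound 3 is therefore estimated at a 1.2-fold lower number from compound 2 to compound 3 (0.07 log units; within the scatter). For compound 3 the inhibition constant in this assay is estimated at 450 nM, in the range 150 nM to 1500 nM.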

Compound 3, inhibition constant: 526 nM
Estimate against measurement, compound 3: 1.2-fold (0.07 log units) below; the measured number falls inside the stated range.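

In this assay, replacing phenyl with 3-methylphenyl gives no change at the digits printed from compound 2 to compound 3 (within the scatter). Within the data shown here, this is the first step that can be read as a single change, and it shows that this place on the six-membered aromatic ring can carry a methyl with no difference that this measurement can separate from its usual scatter. Nothing measured here offers a reason for this flat result.

Going by these compounds, whether a methoxy group, an amine or a carboxylic acid at this same place would also leave the inhibition constant unchanged remains open. A single methyl also cannot show how far this tolerance extends, so a longer chain such as propyl could give a different result.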